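The compounds below may be only part of what the source reports. "The series", "measured", "known", "first", "only" and "open" are said of these compounds alone.

Measured compounds:
compound 1, `COc1ccc(Cl)cc1C(=O)NCC1CCN(S(=O)(=O)NC(=O)NC[C@@H]2C[C@@H]3C=C[C@@H]2C3)CC1` — 15%
compound 2, `COc1ncccc1C(=O)NCCC1CCN(S(=O)(=O)NC(=O)NC2CCCCC2)CC1` — 33%
compound 3, `COc1ccc(C(=O)NCCC2CCN(S(=O)(=O)NC(=O)NC[C@@H]3C[C@@H]4C=C[C@@H]3C4)CC2)cn1` — 11%

In a functional assay on the whole organism (blood) with Rattus norvegicus as the target, with stated times of 24 h and 1 h, at a dose of 5 mg/kg by the intraperitoneal route (on this read-out lower numbers stand for a weaker effect and higher numbers for a stronger effect at the one dose given), compound 2 gives 33%, the highest of the three numbers; compound 1 lies lower by a gap beyond the scatter, and compound 3, the furthest, lower still, also beyond the scatter. Compound 4, `O=C(NC1CCCCC1)NS(=O)(=O)N1CCC(CCNC(=O)c2cccc3c2OCCO3)CC1`, has not been measured. It differs from compound 2 in one place: 2,3-dihydro-1,4-benzodioxin-5-yl in place of 2-methoxypyridin-3-yl on a carbonyl carbon. Going by the values given here, no step between measured compounds covers this change, so no direct guide exists. Given that compound 2 stands alone at the top and the two other amide aryl groups sit lower, the change is expected to cost activity modestly, a step of a number 8 percentage points lower from compound 2 to compound 4 (within the scatter) downward that may stay near the scatter. Compound 4 is expected to give about 25% in this assay, likely between 8% and 45%.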

Compound 4, a percentage reported as activity, at one dose (the size of the read-out at that dose, not a potency): 34%
Compound 4: middle estimate off by 9 percentage points, on the low side, and the stated range covers the measured number.
By their numbers in this assay, from the lowest: compounds 3 and 1 (each within the scatter of the next); then compounds 2 and 4 (each within the scatter of the next).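

In this assay, going by these compounds alone, the first single-place step at this carbonyl carbon, 2,3-dihydro-1,4-benzodioxin-5-yl in place of 2-methoxypyridin-3-yl, is a number 1 percentage points higher from compound 2 to compound 4 (within the scatter). The assay therefore does not separate these two groups at this one dose, even though the entering group has a second ring and no ring nitrogen. Nothing available explains why the two groups read alike.

As far as these compounds go, it remains open whether 2-aminopyridin-3-yl at the same carbonyl carbon would also read alike. From the compounds shown here alone, it is also open whether this swap would read alike with the other end of the molecule as in compound 3.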